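Piperidine to methylpiperazine on the purine-like core

The source may report more compounds than this note shows. Statements on the series, on what has been measured and on what is new or still open speak of the compounds shown alone.

Measured so far:
- compound 1, `Cn1cnc2c(N3CCCCC3)nc(-c3ccccc3O)nc21`: 20%
- compound 2, `CN1CCN(c2nc(-c3ccc(Cl)c(Cl)c3)nc3[nH]cnc23)CC1`: > 80%
- compound 3, `Oc1cccc(-c2nc(N3CCCCC3)c3nc[nH]c3n2)c1`: > 80%

Of the compounds shown here, three have been tested in an assay on cells for displacement of a labelled ligand from adenosine receptor A3 (Homo sapiens), read by scintillation counting and radioligand binding, with a stated time of 180 min, tested at 10 uM; on this read-out higher numbers stand for more inhibition at the one concentration tested (going by the name of the read-out) and lower numbers for less inhibition. Going by the values given here, compound 1 gives 20%, and this is the only value in the set reported as a number. For compound 2 the result is a limit of the assay, > 80%. Compound 3 likewise stops at a limit, > 80%. Two of the three results thus rest at the limit of > 80% in this assay, at which 2 of the 3 values shown sit, so compound 1 stands alone at the low end of what is shown. Among the compounds with values here, no pair among the measured compounds differs in a single place, so no measured step can be drawn on.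

Compound 4, `CN1CCN(c2nc(-c3ccccc3O)nc3c2ncn3C)CC1`, differs from compound 1 in one change: 4-methylpiperazin-1-yl in place of piperidin-1-yl on an aromatic carbon. Compound 2 carries the same 4-methylpiperazin-1-yl group and reaches its limit, but it also differs from compound 4 elsewhere, so its value cannot be read as a guide to this step.

Within the data shown here, with no measured step to lean on, a modest rise beyond the scatter is expected for compound 4, a number 18 percentage points higher from compound 1 to compound 4 (beyond the scatter). Compound 4 is estimated at 38%, with a range from 12% to 70%.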

Compound 4, a percentage reported as inhibition, at one concentration (the size of the read-out at that concentration, not a potency): 15.3%
Estimate against measurement, compound 4: 22.7 percentage points above; measured number inside the range.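

On the core of compound 1, the swap of piperidin-1-yl for 4-methylpiperazin-1-yl on this aromatic carbon gives, in this assay, a number 4.7 percentage points lower from compound 1 to compound 4 (within the scatter), so the two compounds cannot be told apart. Going by these compounds alone, this is the first direct reading of this position, and it shows that, with the 2-hydroxyphenyl group and the rest of the core unchanged, 4-methylpiperazin-1-yl alone does not take the compound out of the low end of the values shown. The earlier compounds shown here could not show this, since compound 2 carries the same 4-methylpiperazin-1-yl group but also differs from compound 4 elsewhere.

As far as these compounds go, whether other groups in this place, such as morpholine, a primary amine or a longer alkyl chain, would move the read-out remains open. Also open, from the compounds shown here alone, is which of the other differences separates compound 1 and compound 4 from compound 2 and compound 3, each of which differs from them in more than one place and gives no number to measure a step against: the limit of > 80% in this assay, at which 2 of the 4 values shown sit.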